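The source may report more compounds than this note shows. Statements on the series, on what has been measured and on what is new or still open speak of the compounds shown alone.

Compound 3 `CCN(CC)c1ccc2cc(C(=O)c3ccc(N4CCN(C(=O)CN5CCN(S(=O)(=O)c6ccc(C(F)(F)F)cc6)CC5)CC4)cc3)oc2c1` stands at the weak end of what this series shows in a functional assay on SGC-7901 cells (Homo sapiens) for cytotoxicity, read by MTT assay, with a stated time of 48 h; a higher number here means a weaker inhibitor, a lower number a stronger inhibitor: compound 3 gives > 40000 nM, which is a limit of the assay rather than a number (the limit of > 40000 nM in this assay, at which 1 of the 3 values shown sits). Compound 2 `CCN(CC)c1ccc2cc(C(=O)c3ccc(N4CCN(C(=O)CN5CCN(S(=O)(=O)c6ccc(OC(F)(F)F)cc6)CC5)CC4)cc3)oc2c1` gives 24400 nM in this assay, and the step of an at least 1.6-fold higher number from compound 2 to compound 3 (0.21 log units; that floor lies within the scatter) stays within the scatter. Among the compounds with values here, compound 1 `CCN(CC)c1ccc2cc(C(=O)c3ccc(N4CCN(C(=O)CN5CCN(C(=O)CCl)CC5)CC4)cc3)oc2c1`, the one chloroacetyl member, gives 1630 nM.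

Compound 4 `CCN(CC)c1ccc2cc(C(=O)c3ccc(N4CCN(C(=O)CN5CCN(S(=O)(=O)c6ccc(F)cc6)CC5)CC4)cc3)oc2c1` follows from compound 3 by fluoro in place of trifluoromethyl on an aromatic carbon. Within the data shown here, the only measured step bearing on an aryl-sulfonyl substituent, an at least 1.6-fold higher number from compound 2 to compound 3 (0.21 log units; that floor lies within the scatter), was small, so no step beyond the scatter is expected in this assay. Compound 4 is therefore expected near 30000 nM, between 8000 nM and 100000 nM, the step of an at least 1.3-fold lower number from compound 3 to compound 4 (0.12 log units; that floor lies within the scatter) being the estimate.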

Compound 4, half-maximal inhibitory concentration: > 40000 nM
Compound 4: no number, only a limit (the forecaster's own chance of this, stated with the estimate: 45%); middle value at least 1.3-fold (0.12 log units) away from the limit.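

Compound 4 joins compound 3 at the limit of this assay, so the step between 4-(trifluoromethyl)phenyl and 4-fluorophenyl cannot be read, and a second para substituent gives no readable value: the limit of > 40000 nM in this assay, at which 2 of the 4 values shown sit.

Against the trifluoromethoxy member, the change gives an at least 1.6-fold higher number from compound 2 to compound 4 (0.21 log units; that floor lies within the scatter). Against the chloroacetyl member, the (4-fluorophenyl)sulfonyl group on the amine nitrogen in a ring gives an at least 24-fold higher number from compound 1 to compound 4 (1.38 log units; beyond the scatter), the one step here beyond the scatter.

On these data alone, whether an amine or a carboxylic acid in place of fluoro gives a readable value stays open. So does whether a plain acetyl on that nitrogen stays close to compound 1.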